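The compounds below may be only part of what the source reports. "The series", "measured", "known", "first", "only" and "open" are said of these compounds alone.

Compound 1 `COc1ccc(CS(=O)(=O)/C=C/c2ccc(OC)c(OC)c2OC)cc1[N+](=O)[O-]` and compound 2 `COc1ccc(CS(=O)(=O)/C=C/c2ccc(OC)c(OC)c2OC)cc1N` share one core. In a functional assay on MCF7 cells (Homo sapiens) for cytotoxicity, read by MTT assay, with a stated time of 72 h (a lower number here means a stronger inhibitor of growth, a higher number a weaker inhibitor of growth), compound 1 gives only a limit of the assay, > 30000 nM. Compound 2 gives 5950 nM in this assay. The change amino in place of nitro on an aromatic carbon made a step of an at least 5.0-fold lower number from compound 1 to compound 2 (0.70 log units; beyond the scatter). Compound 3 `COc1ccc(CS(=O)(=O)CC(=O)Nc2ccccc2)cc1[N+](=O)[O-]` has a different core; the difference between the two cores is not broken down here. In this assay compound 3 gives only a limit, > 30000 nM. Compound 4 `COc1ccc(CS(=O)(=O)CC(=O)Nc2ccccc2)cc1N` carries the same change, (amino in place of nitro on an aromatic carbon), the place being the same word for word. With two of three values sitting at the limit of > 30000 nM in this assay, at which 2 of the 3 values shown sit, the earlier step gives only a floor. For compound 4 the expected step in this assay is an at least 2.0-fold lower number from compound 3 to compound 4 (0.30 log units; that floor lies within the scatter), resting on the step of an at least 5.0-fold lower number from compound 1 to compound 2 (0.70 log units; beyond the scatter) seen on the other core. Compound 4 is estimated at 15000 nM in this assay, with a range from 4000 nM to 40000 nM.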

Compound 4, concentration for 50% growth inhibition: > 30000 nM
Compound 4 was reported as a limit (the forecaster's own chance of this, stated with the estimate: 50%); at least 2.0-fold (0.30 log units) between middle value and limit.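

No step can be read from compound 3 to compound 4 in this assay, since both values are limits: the limit of > 30000 nM in this assay, at which 3 of the 4 values shown sit.

From the compounds shown here alone, whether amino in place of nitro on an aromatic carbon changes growth inhibition on the core of compound 3 stays open.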